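From 2-chlorophenyl to 4-chlorophenyl: working notes

The compounds below may be only part of what the source reports. "The series", "measured", "known", "first", "only" and "open" are said of these compounds alone.

Measured in a functional assay on NUGC-3 cells (Homo sapiens) for cytotoxicity, read by sulforhodamine B assay, with a stated time of 72 h; a higher number here means a weaker inhibitor of growth, a lower number a stronger inhibitor of growth:
- compound 1 `O=C(Nc1cc(C(F)(F)F)cc(C(F)(F)F)c1)C1CCc2ccccc2N1C(=O)c1ccccc1Cl`: 1930 nM
- compound 2 `O=C(Nc1ccc(O)cc1)C1CCc2ccccc2N1`: > 100000 nM (a limit, not a number)

Going by the values given here, compound 1 holds the only actual number in this assay, so the series offers no measured step to compare against. The next compound is compound 3 `O=C(Nc1cc(C(F)(F)F)cc(C(F)(F)F)c1)C1CCc2ccccc2N1C(=O)c1ccc(Cl)cc1`, and its change from compound 1 is 4-chlorophenyl in place of 2-chlorophenyl on a carbonyl carbon. Among the compounds with values here, with no measured step to draw on, the expectation rests on compound 1 at 1930 nM and is for a change in this assay no larger than the scatter, in neither direction. The expected move is a 1.3-fold higher number from compound 1 to compound 3 (0.11 log units; within the scatter). For compound 3 the estimated value is 2500 nM, with an expected range of 800 nM to 8000 nM.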

Compound 3, concentration for 50% growth inhibition: 1660 nM
For compound 3 the middle estimate is 1.5-fold (0.18 log units) above the measured one; low and high end bracket the measured number.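

In this assay, going by these compounds alone, the swap of chlorine position on the phenyl ring gives a 1.2-fold lower number from compound 1 to compound 3 (0.07 log units; within the scatter), the first measured step. At this place, on a carbonyl carbon bound to the ring amide-type nitrogen, 2-chlorophenyl and 4-chlorophenyl cannot be told apart by this read-out.

From the compounds shown here alone, whether a phenyl without chlorine, a methoxyphenyl or a carboxylic acid on this carbonyl carbon would hold the growth inhibition stays open. The reason for so small a step also stays open, since nothing shown bears on it.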